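A Methyl-to-Allyl Step at the Assay Limit

The source may report more compounds than this note shows. Statements on the series, on what has been measured and on what is new or still open speak of the compounds shown alone.

Values measured so far in a functional assay on HeLa cells (Homo sapiens) for antiproliferative activity, read by sulforhodamine B assay (a lower number here means a stronger inhibitor of growth, a higher number a weaker inhibitor of growth), are these:
- Compound 1 `CC(=O)O[C@@H]1[C@@H](OCc2ccccc2)[C@H](OCc2ccccc2)[C@@H](COCc2ccccc2)O[C@H]1C` gives > 50000 nM as a limit
- Compound 2 `CCCC[C@@H]1O[C@H](COCc2ccccc2)[C@@H](OCc2ccccc2)[C@H](OCc2ccccc2)[C@H]1O` gives > 50000 nM as a limit
- Compound 3 `C[C@@H]1O[C@H](COCc2ccccc2)[C@@H](OCc2ccccc2)[C@H](OCc2ccccc2)C1=O` gives > 50000 nM as a limit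

Compound 3 has no true number in this assay because its result of > 50000 nM is a limit and not a measurement. For the measured compounds named here, the overall picture is the limit of > 50000 nM in this assay, at which 3 of the 3 values shown sit, and no compound yet gives an actual number.

Compound 4 `C=CC[C@@H]1O[C@H](COCc2ccccc2)[C@@H](OCc2ccccc2)[C@H](OCc2ccccc2)C1=O` is the next compound to be tested. Its change from compound 3 reads vinyl in place of hydrogen on a saturated chain carbon bound to a saturated ring carbon in full, with vinyl in place of hydrogen on a saturated chain carbon bound to a saturated ring carbon, so that methyl becomes allyl.

Going by the values given here, no measured pair in this set shows what such a change does. The step expected a number no higher from compound 3 to compound 4 (the limit leaves the size open) is therefore none beyond the scatter, with no clear direction. For compound 4 the estimated value is 50000 nM in this set of tests. The expected range for compound 4 runs from 20000 nM to 100000 nM in this estimate.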

Compound 4, concentration for 50% growth inhibition: > 50000 nM
Compound 4 was reported as a limit (the forecaster's own chance of this, stated with the estimate: 75%); the middle value lies on the limit itself.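

No step can be read from compound 3 to compound 4, since both results are limits and not actual numbers: the limit of > 50000 nM in this assay, at which 4 of the 4 values shown sit.

Still open, as far as these compounds go, is whether any compound on the shared core gives an actual number in this assay and what the change from methyl to allyl really does.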